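Two Limits and a Methoxyphenyl Replacement

A few compounds are considered here, and "the series" means these few. Any claim that something is new, unique, unknown or untested is made for them only; others in the source may bear on it.

Compound 1 `CC(C)n1ncc2c(C(=O)NCc3cn(-c4ccc(F)cc4)nn3)cccc21` and compound 2 `Cc1ccccc1-n1cc(CNC(=O)c2cccc3c2cnn3C(C)C)nn1` share a common core and differ only in the group carried on an aromatic nitrogen. In a functional assay on HepG2 cells (Homo sapiens) for inhibition, read by MTT assay, with a stated time of 72 h (on this read-out higher numbers stand for weaker inhibition and lower numbers for stronger inhibition), compound 1 gives > 40000 nM, which is a limit of the assay and not a measured number. In this assay compound 2 likewise gives > 40000 nM, again a limit rather than a number. The step that the two limits leave unreadable from compound 1 to compound 2 therefore cannot be sized, and compound 2 stands only at the limit of > 40000 nM in this assay, at which 2 of the 2 values shown sit, with no readable number of its own. Compound 3 `COc1ccc(-n2cc(CNC(=O)c3cccc4c3cnn4C(C)C)nn2)cc1` carries 4-methoxyphenyl in place of 2-methylphenyl on an aromatic nitrogen. Among the measured compounds shown here, the one measured step is unreadable, so no sized step bears on this change, and the expected outcome is another limit rather than a number. For compound 3 the estimated value is 60000 nM, with a range from 20000 nM to 200000 nM. The estimated step is a step that the limit leaves unreadable from compound 2 to compound 3, expected to be no change beyond the scatter.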

Compound 3, half-maximal inhibitory concentration: > 40000 nM
Compound 3: no number, only a limit (the forecaster's own chance of this, stated with the estimate: 80%); the middle value is on the limit's open side.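

Compound 1, compound 2 and compound 3 all stop at a limit of the assay rather than at a number, so no step among them can be read: the limit of > 40000 nM in this assay, at which 3 of the 3 values shown sit.

The compounds shown leave open how far each lies beyond that limit in this assay, and whether 4-fluorophenyl, 2-methylphenyl and 4-methoxyphenyl differ at all.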